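A few compounds are considered here, and "the series" means these few. Any claim that something is new, unique, unknown or untested is made for them only; others in the source may bear on it.

Compound 1 `COc1ccc(N2C(=O)CSC2c2sc(Cc3ccc(Cl)cc3)nc2C)cc1`: 55.9%
Compound 2 `Cc1nc(-c2ccc(Cl)cc2)sc1C1SCC(=O)N1c1ccc(F)cc1`: 67.6%
Compound 3 `Cc1ccc(N2C(=O)CSC2c2sc(-c3ccc(Cl)cc3)nc2C)cc1`: 63.9%

In a functional assay on the whole organism (strain Wistar albino) for inhibition, with Rattus norvegicus as the target, read by paw edema, with stated times of 1 h and 4 h, at a dose of 40 mg/kg by the oral route (on this read-out higher numbers stand for more inhibition at the one dose given (going by the name of the read-out) and lower numbers for less inhibition), compound 3 stands second highest of these three numbers; compound 2 lies nearest, a number 3.7 percentage points lower from compound 2 to compound 3 (within the scatter), and compound 1 furthest, still within the scatter. Compound 4 `COc1ccc(N2C(=O)CSC2c2sc(-c3ccc(Cl)cc3)nc2C)cc1` differs from compound 3 by methoxy in place of methyl on an aromatic carbon, which one bond further out reads 4-methylphenyl to 4-methoxyphenyl. Going by the values given here, the one measured step, a number 3.7 percentage points lower from compound 2 to compound 3 (within the scatter), also exchanged a group on an aromatic carbon and stayed within the scatter, and compound 1, which carries methoxy too, gives 55.9%, within the scatter of compound 3. No step beyond the scatter is therefore expected for compound 4, a number 2.9 percentage points lower from compound 3 to compound 4 (within the scatter). Compound 4 is estimated at 61%, with a range from 49% to 73%.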

Compound 4, a percentage reported as inhibition, in the whole organism at one dose (the size of the read-out at that dose, not a potency): 59.1%
Estimate against measurement, compound 4: 1.9 percentage points above, and the stated range covers the measured number.
By their numbers in this assay, from the lowest: compounds 1, 4, 3 and 2 (each within the scatter of the next, the first and the last beyond it).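

At this place, para to a large group on the aromatic ring, methoxy joins methyl and fluoro without a step beyond the scatter in this assay (a number 4.8 percentage points lower from compound 3 to compound 4 (within the scatter); a number 8.5 percentage points lower from compound 2 to compound 4 (within the scatter)). With methoxy held there, 4-chlorophenyl in place of 4-chlorobenzyl at the other end of the molecule is also a small step (a number 3.2 percentage points higher from compound 1 to compound 4 (within the scatter)). Nothing measured here gives a reason for these small steps. Going by these compounds, whether an amine or a carboxylic acid at this place would shift the inhibition remains open.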